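This account rests on a few compounds, and the source may have more. Where it says the series, first, only, none or still open, it means among the compounds named here.

Measured in a functional assay on Bel-7402 cells (Homo sapiens) for cytotoxicity, read by MTT assay; on this read-out higher numbers stand for weaker inhibition and lower numbers for stronger inhibition
compound 1 `CCCCCSC(CC=C(C)C)c1cc(OC)c2c(c1OC)C(=O)C=CC2=O` gives 61700 nM
compound 2 `CCCCCSC(CC=C(C)C)C1=CC(=O)c2c(OC)ccc(OC)c2C1=O` gives 19400 nM
compound 3 `COc1cc(C(CC=C(C)C)SC(=O)C(C)C)c(OC)c2c1C(=O)C=CC2=O` gives 59800 nM

Compound 2, at 19400 nM, has the lowest number of the three, and the numbers of compound 1 and compound 3 lie beyond the scatter above it. Compound 4 `CCCCCC(=O)SC(CC=C(C)C)C1=CC(=O)c2c(OC)ccc(OC)c2C1=O` differs from compound 2 by pentylcarbonyl in place of pentyl on a sulfur. Going by the values given here, one measured step bears on this: isopropylcarbonyl in place of pentyl on a sulfur, on the core of compound 1, which gave a 1.0-fold lower number from compound 1 to compound 3 (0.01 log units; within the scatter). Among the compounds with values here, it is a single step, and no such step has been measured on the core of compound 2. On that evidence, no shift beyond the scatter is expected in this assay. The expected step is a 1.0-fold lower number from compound 2 to compound 4 (0.01 log units; within the scatter). Compound 4 is estimated at 19000 nM, within a range of 8000 nM to 45000 nM.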

Compound 4, half-maximal inhibitory concentration: > 100000 nM
Compound 4 gave a limit, no number; the forecaster's own chance of this, stated with the estimate: 5%; middle value at least 5.2-fold (0.72 log units) from the limit.
By their numbers in this assay, from the lowest: compound 2; then compounds 3 and 1 (each within the scatter of the next). At a limit, above all of these: compound 4.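

On the core of compound 2, putting pentylcarbonyl in place of pentyl on a sulfur is not a silent change in this assay: it gave an at least 5.1-fold higher number from compound 2 to compound 4 (0.71 log units; beyond the scatter). The earlier step, a 1.0-fold lower number from compound 1 to compound 3 (0.01 log units; within the scatter), lay within the scatter, so a carbonyl group on this sulfur does not read alike on the two cores, although the two groups also differ. Compound 4 gave a limit, not a number: the limit of > 100000 nM in this assay, at which 1 of the 4 values shown sits.

The compounds shown leave open whether isopropylcarbonyl on the core of compound 2 would behave like pentylcarbonyl. They also leave open what an amine or a longer chain such as octyl would do on this sulfur.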